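Aryl piperazine series: inhibition at a single concentration

A few compounds are considered here, and "the series" means these few. Any claim that something is new, unique, unknown or untested is made for them only; others in the source may bear on it.

Two members of this series have been measured in an assay on CHO cells for displacement of a labelled ligand from adenosine receptor A3 (Homo sapiens), read by scintillation counting, with a stated time of 120 min, tested at 10 uM; on this read-out higher numbers stand for more inhibition at the one concentration tested (going by the name of the read-out) and lower numbers for less inhibition. Compound 1 `Nc1scc(CN2CCN(c3cccc4ccccc34)CC2)c1C(=O)c1ccc(Cl)cc1` gives 0% in this assay, and compound 2 `Nc1scc(CN2CCN(c3cc(F)cc(F)c3)CC2)c1C(=O)c1ccc(Cl)cc1` gives 2% in this assay. For the measured compounds named here, the only step between measured compounds, a number 2 percentage points higher from compound 1 to compound 2 (within the scatter), is within the scatter. Compound 2 therefore holds the highest of the two numbers, but its nearest neighbour, compound 1, sits within the scatter of it, so no order between the two can be read from these numbers.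

Compound 3 `Nc1scc(CN2CCN(c3cccc(Cl)c3)CC2)c1C(=O)c1ccc(Cl)cc1` is the next member. Its difference from compound 2 is 3-chlorophenyl in place of 3,5-difluorophenyl on an amine nitrogen in a ring. Going by the values given here, only the step from compound 1 to compound 2 bears on this change, since it is the one step at the same position of the shared core, and that step was within the scatter; both measured compounds show essentially no inhibition in this assay. Among the compounds with values here, there is no measured step that indicates an exchange at this position moves the read-out beyond the scatter. Compound 3 is therefore expected to give a step of a number 1 percentage points higher from compound 2 to compound 3 (within the scatter) in this assay, with no movement beyond the scatter expected. The estimate for compound 3 in this assay is 3%, with a range from -8% to 16%.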

Compound 3, a percentage reported as inhibition, at one concentration (the size of the read-out at that concentration, not a potency): 1%
Beside the measured number, compound 3's estimate is 2 percentage points above it, within the range that was stated.
By their numbers in this assay, from the lowest: compounds 1, 3 and 2 (each within the scatter of the next).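

In this assay, the exchange on the amine nitrogen in a ring now has two further readings: a number 1 percentage points lower from compound 2 to compound 3 (within the scatter), and a number 1 percentage points higher from compound 1 to compound 3 (within the scatter). The position has thus taken naphthalen-1-yl, 3,5-difluorophenyl and 3-chlorophenyl, and no step among these three aryl groups leaves the scatter, so the change from two fluorine atoms to one chlorine atom on the phenyl ring gives no separable reading, and neither does the change from the naphthalen-1-yl group to 3-chlorophenyl. No supporting information bears on this flat result.

The compounds shown leave open whether anything other than an aryl group at this nitrogen, such as a longer chain ending in an amine or a carboxylic acid, would give a step beyond the scatter in this assay. They also leave open whether the flat readings hold when the other places of the shared core, which are identical in all three compounds, carry different groups, and a reading at one concentration says nothing about potency.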